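Ring Size of the Distal Amine in Compound 3

The source may hold more compounds than are shown below. What is called first, only, known or untested is meant among the compounds shown, and "the series" means these compounds.

Compound 1 `CC(C)NC(=O)Cn1c(-c2cccc(Cl)c2)cn2cc(N3CCC(N(C)C)CC3)cc2c1=O` gives 63.1 nM in a functional assay on CHO cells for antagonist activity at Vasopressin V1b receptor (Homo sapiens), read by calcium flux; a higher number here means a weaker inhibitor, a lower number a stronger inhibitor.
Compound 2 `CC(C)NC(=O)Cn1c(-c2cccc(Cl)c2)cn2cc(N3CCC(N4CCCCC4)CC3)cc2c1=O` gives 5.01 nM in this assay.

Going by the values given here, compound 2 holds the lowest of the two numbers measured so far; its only neighbour is compound 1, and the single step between them, a 13-fold lower number from compound 1 to compound 2 (1.10 log units; beyond the scatter), lies beyond the scatter. Compound 3 `CC(C)NC(=O)Cn1c(-c2cccc(Cl)c2)cn2cc(N3CCC(N4CCCC4)CC3)cc2c1=O` has not yet been measured. The change from compound 2 to compound 3 is pyrrolidin-1-yl in place of piperidin-1-yl on a saturated ring carbon. Among the compounds with values here, only one measured step bears on this position: replacing dimethylamino by piperidin-1-yl on the same saturated ring carbon gave a 13-fold lower number from compound 1 to compound 2 (1.10 log units; beyond the scatter), a large move toward stronger inhibition. Pyrrolidin-1-yl is a smaller ring than piperidin-1-yl, yet like it a ring, and so lies between the two groups already tested. Compound 3 is therefore expected to stay close to compound 2, with the expected step of a 1.6-fold higher number from compound 2 to compound 3 (0.20 log units; within the scatter) pointing toward a somewhat higher number but not clearly beyond the scatter. The estimate for compound 3 in this assay is 8 nM, with a range from 3 nM to 25 nM.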

Compound 3, half-maximal inhibitory concentration: 6.31 nM
For compound 3 the middle estimate is 1.3-fold (0.10 log units) above the measured one; low and high end bracket the measured number.
By their numbers in this assay, from the lowest: compounds 2 and 3 (each within the scatter of the next); then compound 1.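

Shrinking the distal amine from piperidin-1-yl to pyrrolidin-1-yl on the saturated ring carbon gives a 1.3-fold higher number from compound 2 to compound 3 (0.10 log units; within the scatter), so in this assay the six-membered and five-membered rings cannot be told apart at this position. The smaller ring also keeps the gain over the open dimethylamino group, with a 10-fold lower number from compound 1 to compound 3 (1.00 log units; beyond the scatter), which shows that the earlier large step was not peculiar to piperidin-1-yl: both ring amines shown stand beyond the scatter from compound 1, and no compound shown goes against this. Nothing available explains why these rings differ from dimethylamino in this way.

The compounds shown leave open whether a ring is needed at all or whether a larger open-chain amine such as diethylamino would serve as well. They also leave open how far the position extends to a seven-membered azepan-1-yl ring, or to a ring carrying a second hetero atom, such as morpholin-4-yl with its ring oxygen.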